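The compounds below may be only part of what the source reports. "The series", "measured", "known", "first", "only" and "open" are said of these compounds alone.

Measured so far:
- compound 3 `CC(C)CN(C)CC[C@@H](CC(=O)NC1CCC1)NC(=O)c1cc(-c2ccccc2C(F)(F)F)n(C2CCCC2)n1`: 63.6%
- compound 1 `CS(=O)(=O)c1ccccc1-c1cc(C(=O)N[C@@H](CCN2CCCCC2)CC(=O)NC2CCC2)nn1C1CCCC1`: "nd" (no result reported)
- compound 2 `O=C(C[C@H](CCN1CCCCC1)NC(=O)c1cc(-c2cscn2)n(C2CCCC2)n1)NC1CCC1`: "nd" (no result reported)

Among the compounds with values here, in an ADME assay on microsomes from liver (Rattus norvegicus, strain Sprague-Dawley) for metabolic stability, read by LC-MS, using NADPH, with a stated time of 30 min, tested at 1 uM (a higher number here means that more of the compound is left, a lower number that less of the compound is left), compound 3 is the only compound with a reported number; compound 1 and compound 2 carry no result, so no step between measured compounds can be drawn and compound 3 stands alone. Compound 4 `O=C(C[C@H](CCN1CCCCC1)NC(=O)c1cc(-c2ccccc2C(F)(F)F)n(C2CCCC2)n1)NC1CCC1` is the next entry for this assay. It differs from compound 3 by piperidin-1-yl in place of isobutyl(methyl)amino on a saturated chain carbon, three bonds along the chain from an amide-type nitrogen. Without a measured step of this kind, no direction can be read from the data; a step of modest size is expected, a number 5.6 percentage points lower from compound 3 to compound 4 (within the scatter), most likely not beyond the scatter. Compound 4 is accordingly estimated to give 58% in this assay, with a range from 35% to 82%.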

Compound 4, percent of the compound remaining: 74.6%
Compound 4: middle estimate off by 16.6 percentage points, on the low side, within the range that was stated.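

In this assay, piperidin-1-yl in place of isobutyl(methyl)amino gives a number 11 percentage points higher from compound 3 to compound 4 (beyond the scatter), so the read-out responds to the form of the amine at this place on the chain. The two groups hold the same count of 6 heavy atoms, and they differ in the six-membered ring of piperidin-1-yl. No measurement shown here accounts for the step. Steps to compound 1 and compound 2 cannot be read. Going by these compounds, whether a morpholine or pyrrolidine at this place, or a longer chain leading to the amine, would follow compound 4 remains open.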